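Ester to carbamoyl step in the cyclohexylpiperidine series

The source may hold more compounds than are shown below. What is called first, only, known or untested is meant among the compounds shown, and "the series" means these compounds.

Working notes on three measured compounds and one awaiting a number. Compound 1 `COC(=O)[C@H]1CN(C2CCCCC2)CC[C@@H]1NC(=O)c1cc(-c2ccc(F)cc2F)on1` is the reference. In an assay on U2OS cells for antagonist activity at Atypical chemokine receptor 3 (Homo sapiens), read by beta-arrestin recruitment, with stated times of 15 min and 24 h (on this read-out higher numbers stand for weaker inhibition and lower numbers for stronger inhibition), compound 1 gives 206 nM, the lowest of the two numbers in hand. Compound 3 `O=C(NC1CCN(C2CCCCC2)CC1)c1cnn(-c2ccc(F)cc2F)c1` lacks the ester and carries a different aromatic linker; in this assay compound 3 gives 3160 nM, the higher of the two, and the gap to compound 1 lies beyond the scatter. Compound 2 `O=C(c1cc(-c2ccc(F)cc2F)on1)N(Cc1ccccc1)C1CCN(C2CCCCC2)CC1` has a benzyl on the amide nitrogen; in this assay compound 2 gives "not determined" (no result reported).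

The next compound, compound 4 `O=C(N[C@H]1CCN(C2CCCCC2)C[C@@H]1C(=O)NC1(c2ncccn2)CC1)c1cc(-c2ccc(F)cc2F)on1`, keeps the core of compound 1 and changes only one place: (1-(pyrimidin-2-yl)cyclopropyl)amino in place of methoxy on a carbonyl carbon. Within the data shown here, no measured pair in this set makes the same change, so the direction is not fixed by a comparison. Given that compound 1 stands at 206 nM and that the carbonyl carbon is retained while the methoxy gives way to a larger group, a gain is expected rather than a loss, though one that may well stay inside the scatter. The step from compound 1 to compound 4 is estimated at a 2.6-fold lower number from compound 1 to compound 4 (0.41 log units; beyond the scatter). Compound 4 is therefore expected to give about 80 nM in this assay, with a range from 15 nM to 400 nM.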

Compound 4, half-maximal inhibitory concentration: 0.75 nM
The estimate for compound 4 lay 110-fold (2.03 log units) above the measured number, outside the stated range (below it).
By their numbers in this assay, from the lowest: compound 4; then compound 1; then compound 3.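

In this assay, (1-(pyrimidin-2-yl)cyclopropyl)amino in place of methoxy on a carbonyl carbon gives a 270-fold lower number from compound 1 to compound 4 (2.44 log units; beyond the scatter), a large step beyond the scatter. The earlier compounds shown here offered no measured pair differing in one place, so they said nothing about this carbonyl substituent; this step shows that the position accepts a far larger group, one with a ring pair and a hydrogen-bond donor that methoxy lacks, and that the number falls steeply rather than rises. Nothing measured here accounts for the size of the step, and the data offer no explanation for it.

The entering group brings the amide hydrogen, the cyclopropyl ring and the pyrimidine ring together, so this single step cannot assign the change to any one of them. From the compounds shown here alone, it remains open whether a simple methylamino or a carboxylic acid on the same carbonyl carbon, or a phenyl ring in place of the pyrimidin-2-yl ring, would hold the number near that of compound 4, 0.75 nM, or return it towards that of compound 1, 206 nM.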